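Replacing (4-iodophenyl)amino with pyrrolidin-1-yl

The compounds below may be only part of what the source reports. "The series", "measured", "known", "first", "only" and "open" are said of these compounds alone.

Measured in a functional assay on MCF7 cells (Homo sapiens) for inhibition, read by sulforhodamine B assay; a higher number here means a weaker inhibitor, a lower number a stronger inhibitor:
- compound 1 `Cc1ccc(NC2=CC(=O)c3nc4n(c3C2=O)[C@H]2OC[C@@H](O)[C@H]2OC4)cc1C`: 2080 nM
- compound 2 `O=C1C=C(Nc2ccc(I)cc2)C(=O)c2c1nc1n2[C@H]2OC[C@@H](O)[C@H]2OC1`: 2230 nM

For the measured compounds named here, compound 2 cannot be ordered against compound 1, since the only measured step, a 1.1-fold higher number from compound 1 to compound 2 (0.03 log units; within the scatter), stays within the scatter. Compound 3 `O=C1C=C(N2CCCC2)C(=O)c2c1nc1n2[C@H]2OC[C@@H](O)[C@H]2OC1` differs from compound 2 by pyrrolidin-1-yl in place of (4-iodophenyl)amino on a double-bonded ring carbon. Going by the values given here, no measured compound carries pyrrolidin-1-yl, so that single step sets neither size nor direction here, and no clear shift is expected. The expected change is a 1.1-fold higher number from compound 2 to compound 3 (0.05 log units; within the scatter). For compound 3 the estimate is 2500 nM, with an expected range from 700 nM to 9000 nM.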

Compound 3, half-maximal inhibitory concentration: > 16000 nM
Compound 3 ended at the assay's limit; the forecaster's own chance of this, stated with the estimate: 10%; at least 6.4-fold (0.80 log units) between middle value and limit.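

Compound 3 sits at a limit of this assay, not at a number: the limit of > 16000 nM in this assay, at which 1 of the 3 values shown sits. The double-bonded ring carbon therefore does respond to its substituent: pyrrolidin-1-yl in place of (4-iodophenyl)amino gives an at least 7.1-fold higher number from compound 2 to compound 3 (0.85 log units; beyond the scatter), and in place of (3,4-dimethylphenyl)amino it gives an at least 7.6-fold higher number from compound 1 to compound 3 (0.88 log units; beyond the scatter). The earlier pair, with a 1.1-fold higher number from compound 1 to compound 2 (0.03 log units; within the scatter), showed no such response.

Pyrrolidin-1-yl replaces the phenyl ring and the amine hydrogen together, and the compounds shown do not tell which of the two matters. They also leave open how a cyclopentylamino group, which keeps that hydrogen without the phenyl ring, would read.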